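Chloro to Trifluoromethyl on a Series That Shows No Binding

The compounds below may be only part of what the source reports. "The series", "measured", "known", "first", "only" and "open" are said of these compounds alone.

Compound 1, `CC(C)(C)Cc1csc(N)c1C(=O)c1cccc(C(F)(F)F)c1`: 1%
Compound 2, `CC(C)(C)Cc1c(-c2ccccc2)sc(N)c1C(=O)c1cccc(C(F)(F)F)c1`: 1%
Compound 3, `COc1ccc(-c2sc(N)c(C(=O)c3cccc(Cl)c3)c2CC(C)(C)C)cc1`: 1%

All three measured compounds were tested in an assay on CHO cells for displacement of a labelled ligand from adenosine receptor A1 (Homo sapiens), read by scintillation counting, tested at 10 uM (a lower number here means less inhibition, a higher number more inhibition at the concentration tested (going by the name of the read-out)), and all three sit at the same level, essentially showing no displacement. Compound 3 stands level with compound 1 and compound 2 within the scatter. Among the compounds with values here, the one measured step, no change at the digits printed from compound 1 to compound 2 (within the scatter), shows that adding a phenyl to the shared core leaves the read-out untouched.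

The unmeasured compound 4, `COc1ccc(-c2sc(N)c(C(=O)c3cccc(C(F)(F)F)c3)c2CC(C)(C)C)cc1`, differs from compound 3 in one place: trifluoromethyl in place of chloro on an aromatic carbon. Within the data shown here, no measured pair shows this exact change. What the data do show is that compound 1 and compound 2 already carry the trifluoromethyl group that enters here, and both give the same near-zero inhibition as the chloro-bearing compound 3. Among the measured compounds shown here, nothing among the measured compounds suggests that either group, or any other change so far, moves this assay. The step from compound 3 to compound 4 is therefore expected to be a number 1 percentage points higher from compound 3 to compound 4 (within the scatter), with no change beyond the scatter. Compound 4 is estimated to give 2% in this assay, between -8% and 12%.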

Compound 4, a percentage reported as inhibition, at one concentration (the size of the read-out at that concentration, not a potency): 2%
Compound 4: middle estimate and measured number agree at the digits printed; the range from low to high includes it.
By their numbers in this assay, from the lowest: compounds 1, 2, 3 and 4 (each within the scatter of the next).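

The direct pair now measures the exchange on a single background: at this place, on an aromatic carbon of a six-membered aromatic ring of carbon only, putting trifluoromethyl in place of chloro gives a number 1 percentage points higher from compound 3 to compound 4 (within the scatter) in this assay, so this change does not separate the two compounds. The other new steps show the same for the group at the far end of the molecule: methoxy in place of hydrogen gives a number 1 percentage points higher from compound 2 to compound 4 (within the scatter), and 4-methoxyphenyl in place of hydrogen gives a number 1 percentage points higher from compound 1 to compound 4 (within the scatter), so neither addition lifts the read-out clear of the scatter when trifluoromethyl is present. No outside measurement is available to explain this flat result.

The compounds shown leave open whether a group of a different kind at the same place, such as a carboxylic acid or a nitrile, would produce a step beyond the scatter. On these data alone, with all four compounds sitting this close to zero, it also remains open whether chloro and trifluoromethyl would differ on a compound that shows clear displacement.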